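This account rests on a few compounds, and the source may have more. Where it says the series, first, only, none or still open, it means among the compounds named here.

Of the compounds shown here, three with a shared core have been tested in an assay on cells for displacement of a labelled ligand from adenosine receptor A1 (Homo sapiens), read by scintillation counting, with a stated time of 120 min, tested at 1 uM; a lower number here means less inhibition, a higher number more inhibition at the concentration tested (going by the name of the read-out). Compound 1 `COc1ccc(C(=O)Nc2nccn3cc(-c4ccccc4)nc23)cc1` gives 1% in this assay. Compound 3 `COc1ccc(C(=O)Nc2nc(-c3ccccc3)cn3cc(-c4ccccc4)nc23)cc1` gives 6% in this assay. The change between them is phenyl in place of hydrogen on an aromatic carbon and the step it made is a number 5 percentage points higher from compound 1 to compound 3 (within the scatter).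

Compound 2 `COc1ccc(-c2cn3ccnc(NC(=O)c4ccccc4)c3n2)cc1` gives 1% in this assay. Compound 1 and compound 2 have the same atoms joined differently; the difference between the two cores is not broken down here. Their two numbers stand level at the digits given.

Compound 4 `COc1ccc(-c2cn3cc(-c4ccccc4)nc(NC(=O)c4ccccc4)c3n2)cc1` has not yet been measured. It differs from compound 2 by phenyl in place of hydrogen on an aromatic carbon. This is the same kind of change as that from compound 1 to compound 3, though the place is described a little differently: in compound 4 the new phenyl sits meta to a benzamido group, where for compound 3 it sits meta to a large group. Because the earlier step was a number 5 percentage points higher from compound 1 to compound 3 (within the scatter), the step from compound 2 to compound 4 is expected to be small, about a number 4 percentage points higher from compound 2 to compound 4 (within the scatter). Compound 4 is estimated to give about 5%, somewhere between 0% and 15%.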

Compound 4, a percentage reported as inhibition, at one concentration (the size of the read-out at that concentration, not a potency): 3%
Compound 4: the middle estimate sits 2 percentage points above what was measured; measured number inside the range.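

On the second core, the phenyl gives a small step in this assay, a number 2 percentage points higher from compound 2 to compound 4 (within the scatter), and the two steps agree as far as these numbers can tell: the same change on two cores in this assay, a number 5 percentage points higher (within the scatter) from compound 1 to compound 3 and a number 2 percentage points higher (within the scatter) from compound 2 to compound 4, 3 percentage points apart, within the scatter of two such steps. In this pair of cores, then, the change carries over in a modest sense: on both, swapping hydrogen for phenyl leaves the inhibition within the usual scatter. This does not show that phenyl has a real effect on either core, and two small steps measured at a single concentration say nothing about potency or about whether the cores would still match if a change had a larger effect.

From the compounds shown here alone, only hydrogen and phenyl appear at this place, so it remains open whether an amine, a carboxylic acid or a longer alkyl chain there would move the inhibition beyond the scatter. Going by these compounds, it also remains open whether the two cores would respond alike to such a group.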